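Compound 3 to compound 4: a 1H-pyrrol-2-yl amide

The compounds below may be only part of what the source reports. "The series", "measured", "known", "first", "only" and "open" are said of these compounds alone.

In a functional assay on NCI-H1650 cells (Homo sapiens) for inhibition, read by sulforhodamine B assay, with a stated time of 3 days (a lower number here means a stronger inhibitor, a higher number a weaker inhibitor), compound 1 `COc1ccc(C(=O)Nc2ccc3c(c2)/C(=C/Nc2cccc(N4CCN(C)CC4)c2)C(=O)N3)cc1` gives 1870 nM, compound 2 `CN1CCN(c2cccc(N/C=C3\C(=O)Nc4ccc(NC(=O)c5cccc(F)c5)cc43)c2)CC1` gives 4280 nM and compound 3 `CN1CCN(c2cccc(N/C=C3\C(=O)Nc4ccc(NC(=O)c5c(Cl)cccc5Cl)cc43)c2)CC1` gives 2170 nM. Compound 3 lies within the scatter of both other compounds, so its number cannot be separated from either.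

Compound 4 `CN1CCN(c2cccc(N/C=C3\C(=O)Nc4ccc(NC(=O)c5ccc[nH]5)cc43)c2)CC1` differs from compound 3 on a carbonyl carbon whose other neighbour is the amide-type nitrogen: 1H-pyrrol-2-yl in place of 2,6-dichlorophenyl on a carbonyl carbon. In words, 1H-pyrrol-2-yl stands in place of 2,6-dichlorophenyl.

Three measured steps change this same group. The results are a 1.2-fold higher number from compound 1 to compound 3 (0.06 log units; within the scatter) and a 2.0-fold lower number from compound 2 to compound 3 (0.29 log units; within the scatter), both within the scatter, and a 2.3-fold higher number from compound 1 to compound 2 (0.36 log units; beyond the scatter), a modest step beyond it. None of them brings in a five-membered aromatic ring, so the evidence is indirect. Since these steps are all small, no step beyond the scatter is expected in this assay, in either direction. The expected change is a 1.2-fold higher number from compound 3 to compound 4 (0.06 log units; within the scatter).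

Compound 4 is estimated at 2500 nM, with an expected range of 900 nM to 7000 nM.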

Compound 4, half-maximal inhibitory concentration: 7560 nM
Compound 4: the middle estimate sits 3.0-fold (0.48 log units) below what was measured, and the stated range ends below it.
By their numbers in this assay, from the lowest: compounds 1, 3, 2 and 4 (each within the scatter of the next, the first and the last beyond it).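

In this assay the group on the carbonyl carbon proves able to shift the number beyond the scatter, with 1H-pyrrol-2-yl in place of the six-membered aromatic rings giving modest steps (a 3.5-fold higher number from compound 3 to compound 4 (0.54 log units; beyond the scatter); a 4.0-fold higher number from compound 1 to compound 4 (0.61 log units; beyond the scatter)). The effect does not hold against every earlier group, since the step from 3-fluorophenyl stays within the scatter (a 1.8-fold higher number from compound 2 to compound 4 (0.25 log units; within the scatter)), so compound 4 cannot be separated from compound 2. Nothing measured here accounts for these steps.

Open, from the compounds shown here alone, is whether 1-methyl-1H-pyrrol-2-yl or furan-2-yl on the same carbonyl carbon would read like compound 4 or like compound 3, which would test the pyrrole hydrogen on nitrogen against the ring itself. Also open, going by these compounds, is how a non-aromatic group, such as a dimethylaminomethyl chain, would read at this place.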